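The source may report more compounds than this note shows. Statements on the series, on what has been measured and on what is new or still open speak of the compounds shown alone.

Series notes. The shared core of compound 1 `Cc1cn([C@@H]2O[C@H](CO[Si](C)(C)C(C)(C)C)[C@@]3(OS(=O)(=O)C=C3N)[C@H]2O[Si](C)(C)C(C)(C)C)c(=O)n(Cc2ccccc2)c1=O` carries a phenyl on the saturated chain carbon bound to the aromatic nitrogen; in a functional assay on CCRF-CEM cells (Homo sapiens) (on this read-out higher numbers stand for lower toxicity in this test and lower numbers for higher toxicity in this test), compound 1 gives 53000 nM. Compound 2 `CNC(=O)Cn1c(=O)c(C)cn([C@@H]2O[C@H](CO[Si](C)(C)C(C)(C)C)[C@@]3(OS(=O)(=O)C=C3N)[C@H]2O[Si](C)(C)C(C)(C)C)c1=O` carries methylcarbamoyl at that place. In this assay compound 2 reaches only a limit of the assay, >= 250000 nM, and no number. Compound 3 `Cc1cn([C@@H]2O[C@H](CO[Si](C)(C)C(C)(C)C)[C@@]3(OS(=O)(=O)C=C3N)[C@H]2O[Si](C)(C)C(C)(C)C)c(=O)n(CCCNC(=O)OCc2ccccc2)c1=O` gives 229000 nM in this assay. Going by the values given here, the one measured step within the set is an at least 4.7-fold higher number from compound 1 to compound 2 (0.67 log units; beyond the scatter), and compound 2 stands at the limit (the limit of >= 250000 nM in this assay, at which 1 of the 3 values shown sits), so no numbered comparison is available from it. Compound 4 `Cc1cn([C@@H]2O[C@H](CO[Si](C)(C)C(C)(C)C)[C@@]3(OS(=O)(=O)C=C3N)[C@H]2O[Si](C)(C)C(C)(C)C)c(=O)n(CCCN(CC(=O)O)CC(=O)O)c1=O` is unmeasured; its difference from compound 2 is 2-(bis(carboxymethyl)amino)ethyl in place of methylcarbamoyl on a saturated chain carbon bound to an aromatic nitrogen. Among the compounds with values here, no measured step bears on this change directly; with compound 2 at the limit and compound 3 giving a number of a similar size, no step beyond the scatter is expected in this assay, with the result most likely again reported only as a limit. In this assay compound 4 is expected at 250000 nM, between 100000 nM and 600000 nM. The expected step is a number no higher from compound 2 to compound 4 (the limit leaves the size open).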

Compound 4, half-maximal cytotoxic concentration: > 250000 nM
Compound 4 was reported as a limit (the forecaster's own chance of this, stated with the estimate: 70%); the middle value sits exactly at the limit.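

On the saturated chain carbon bound to an aromatic nitrogen, this assay now shows that 2-(bis(carboxymethyl)amino)ethyl also stands apart from phenyl: an at least 4.7-fold higher number from compound 1 to compound 4 (0.67 log units; beyond the scatter). Against the (benzyloxycarbonyl)amino end of compound 3, the exchange for bis(carboxymethyl)amino gives an at least 1.0-fold higher number from compound 3 to compound 4 (0.03 log units; that floor lies within the scatter), so no order between these two compounds can be stated. The step from compound 2 to compound 4 cannot be read because both compounds end at limits, not numbers: the limit of >= 250000 nM in this assay, at which 1 of the 4 values shown sits.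

The compounds shown leave open whether phenyl alone sets compound 1 apart, or whether a plain propyl chain ending in a free amine or a single carboxylic acid would sit with compound 3 and compound 4. Also open, on these data alone, is how compound 2 and compound 4 compare beyond the limit of the assay.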